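The source may report more compounds than this note shows. Statements on the series, on what has been measured and on what is new or still open speak of the compounds shown alone.

Compound 1 `O=C(/C=C/c1ccccc1)NS(=O)(=O)c1ccccc1`: 3.5 ug/mL
Compound 2 `O=C(/C=C/c1ccccc1)NS(=O)(=O)c1ccc(Cl)cc1`: 2.2 ug/mL

Among these two numbers in a functional assay on B16-F10 cells (Mus musculus) for antiproliferative activity, read by ELISA and MTT assay, with a stated time of 48 h (on this read-out higher numbers stand for weaker inhibition and lower numbers for stronger inhibition), compound 1 stands highest, with compound 2 nearest, though the change a 1.6-fold lower number from compound 1 to compound 2 (0.20 log units; within the scatter) lies within the scatter. Compound 3 `O=C(/C=C/c1ccccc1[N+](=O)[O-])NS(=O)(=O)c1ccccc1` differs from compound 1 by nitro in place of hydrogen on an aromatic carbon. Within the data shown here, the only measured step, a 1.6-fold lower number from compound 1 to compound 2 (0.20 log units; within the scatter), concerns the other ring and a different group, so nothing measured bears directly on this change. The expectation is therefore no step beyond the scatter. Compound 3 is estimated at 3.5 ug/mL, within 1.5 ug/mL to 8 ug/mL. This estimate means a step of no change at the digits printed from compound 1 to compound 3 (within the scatter).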

Compound 3, half-maximal inhibitory concentration: 6 ug/mL
Compound 3: the middle estimate sits 1.7-fold (0.23 log units) below what was measured; low and high end bracket the measured number.
By their numbers in this assay, from the lowest: compounds 2, 1 and 3 (each within the scatter of the next, the first and the last beyond it).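

In this assay, nitro in place of hydrogen on an aromatic carbon, ortho to a large group, gives a 1.7-fold higher number from compound 1 to compound 3 (0.23 log units; within the scatter), so a group of three heavy atoms can stand at this position on the ring that compound 2 leaves unchanged without a step beyond the scatter. No measured evidence bears on why this change has so small an effect.

The compounds shown leave open whether an amine, a methoxy group or a carboxylic acid at this same position would give a step beyond the scatter. They also leave open how nitro would behave elsewhere on this ring.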